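The compounds below may be only part of what the source reports. "The series", "measured", "known", "first", "only" and "open" are said of these compounds alone.

Working notes on the series. In a functional assay on DU-145 cells (Homo sapiens) for cytotoxicity (a lower number here means a stronger inhibitor of growth, a higher number a weaker inhibitor of growth), compound 1 (`COc1ccc(C2=C(c3ccc(SC)cc3)CC3CCCN3C2=O)cc1OC(=O)C1CCCN1C(=O)OC(C)(C)C`) gives 5000 nM and compound 2 (`CSc1ccc(C2=C(c3ccc(F)c(C)c3)C(=O)N3CCCC3C2)cc1`) gives 500 nM. Compound 2 holds the lower of the two numbers, and the gap between them lies beyond the usual scatter. The two compounds differ in more than one place, so this gap does not isolate any single change.

Compound 3 (`CSc1ccc(C2=C(c3ccc(C)cc3)C(=O)N3CCCC3C2)cc1`) departs from compound 2 in one place: 4-methylphenyl in place of 4-fluoro-3-methylphenyl on a double-bonded ring carbon. It has 4-methylphenyl in place of 4-fluoro-3-methylphenyl on a double-bonded ring carbon, and the rest of the structure is unchanged.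

Within the data shown here, the series holds no measured step for this change, so the expectation is only loosely grounded. No shift beyond the scatter is expected in this assay, and the estimated move is a 1.2-fold higher number from compound 2 to compound 3 (0.08 log units; within the scatter). For compound 3 the expected value is 600 nM, with an estimated range of 200 nM to 1800 nM.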

Compound 3, concentration for 50% growth inhibition: 600 nM
Beside the measured number, compound 3's estimate shows no gap at the digits printed; the measured number falls inside the stated range.
By their numbers in this assay, from the lowest: compounds 2 and 3 (each within the scatter of the next); then compound 1.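

Among these compounds, this is the first step that can be read at a single place: in this assay, 4-methylphenyl in place of 4-fluoro-3-methylphenyl on the double-bonded ring carbon gives a 1.2-fold higher number from compound 2 to compound 3 (0.08 log units; within the scatter), a shift within the scatter. For this pair, then, the position accepts either group with no distinguishable change in growth inhibition, and the fluorine-bearing aryl group is not needed to keep the number at this level. No available evidence bears on why the two groups read alike.

From the compounds shown here alone, the two groups compared here are both methyl-bearing phenyl rings, so the effect of a carboxylic acid, an amine or a longer alkyl chain at this position remains open. Also open, going by these compounds, is whether the same swap would read alike on the core of compound 1.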